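The source may hold more compounds than are shown below. What is called first, only, known or untested is meant among the compounds shown, and "the series" means these compounds.

Measured in a functional assay on Vero cells (Chlorocebus sabaeus) for inhibition; on this read-out higher numbers stand for weaker inhibition and lower numbers for stronger inhibition:
- Compound 1 `COc1cc(/C=C/C(=O)c2cccc(NC(=O)c3cc(Cl)cc(Cl)c3)c2)ccc1O`: > 50 ug/mL, a limit
- Compound 2 `COc1cc(/C=C/C(=O)c2cccc(NC(=O)c3ccc(Cl)c(Cl)c3)c2)ccc1O`: > 50 ug/mL, a limit
- Compound 3 `CCCC(=O)Nc1cccc(C(=O)/C=C/c2ccc(O)c(OC)c2)c1`: 2.04 ug/mL

For the measured compounds named here, compound 3 carries the only true number here, since the other two results stand at the limit of > 50 ug/mL in this assay, at which 2 of the 3 values shown sit.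

Compound 4 `COc1cc(/C=C/C(=O)c2cccc(NC(C)=O)c2)ccc1O` differs from compound 3 by hydrogen in place of ethyl on a saturated chain carbon bound to a carbonyl carbon, which turns propyl into methyl. Going by the values given here, two measured steps bear on this carbonyl substituent: an at least 24-fold lower number from compound 1 to compound 3 (1.38 log units; beyond the scatter) and an at least 24-fold lower number from compound 2 to compound 3 (1.38 log units; beyond the scatter). Among the compounds with values here, both are large, but both start from a dichlorophenyl group, and no measured step shortens a chain. Only a small move toward weaker inhibition in this assay is therefore expected, perhaps within the scatter. The estimated change runs a 2.0-fold higher number from compound 3 to compound 4 (0.29 log units; within the scatter). For compound 4 the estimated value is 4 ug/mL, with an expected range of 1 ug/mL to 20 ug/mL.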

Compound 4, half-maximal inhibitory concentration: 14.5 ug/mL
Compound 4: middle estimate off by 3.6-fold (0.56 log units), on the low side; the range from low to high includes it.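

In this assay shortening propyl to methyl on the carbonyl carbon is itself a step beyond the scatter (a 7.1-fold higher number from compound 3 to compound 4 (0.85 log units; beyond the scatter)), so chain length at this position matters, not only the choice between a chain and a dichlorophenyl group. Compound 4 still stays apart from both dichlorophenyl compounds (an at least 3.4-fold lower number from compound 2 to compound 4 (0.53 log units; beyond the scatter)) and (an at least 3.4-fold lower number from compound 1 to compound 4 (0.53 log units; beyond the scatter)). The true size of these two gaps cannot be read, since they rest on a limit: the limit of > 50 ug/mL in this assay, at which 2 of the 4 values shown sit.

The compounds shown leave open whether a longer chain such as pentyl would lower the number further. They also leave open whether an unsubstituted phenyl on the carbonyl carbon would behave like the dichlorophenyl groups.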